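Nitro to amino on two related cores

This account rests on a few compounds, and the source may have more. Where it says the series, first, only, none or still open, it means among the compounds named here.

In a functional assay on T47D cells (Homo sapiens) for antiproliferative activity, read by MTT assay, with a stated time of 72 h (a higher number here means a weaker inhibitor, a lower number a stronger inhibitor), the three measured compounds stand as follows:
compound 1, `COc1ccc(NC(=O)c2cc(OC)c(OC)c(OC)c2)cc1[N+](=O)[O-]`, gives 34500 nM;
compound 2, `COc1ccc(NC(=O)c2cc(OC)c(OC)c(OC)c2)cc1N`, gives 50400 nM;
compound 3, `COc1ccc(OC(=O)c2cc(OC)c(OC)c(OC)c2)cc1[N+](=O)[O-]`, gives only a limit, > 100000 nM.

Compound 1 and compound 2 share one core and differ in a single place: amino in place of nitro on an aromatic carbon. The step this change made is a 1.5-fold higher number from compound 1 to compound 2 (0.16 log units; within the scatter), so the two values lie within the scatter of each other and no order can be read between them. Compound 3 carries a different core, and the difference between the two cores is not broken down here. For compound 3 the value is a limit of the assay, not a number; it rests at the limit of > 100000 nM in this assay, at which 1 of the 3 values shown sits.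

The unmeasured compound 4, `COc1ccc(OC(=O)c2cc(OC)c(OC)c(OC)c2)cc1N`, stands to compound 3 exactly as compound 2 stands to compound 1: amino in place of nitro on an aromatic carbon. Both place descriptions read the same, so this is the same change on the other core. Compound 4 is therefore expected to show a step that the limit leaves unreadable from compound 3 to compound 4, resting on the within-scatter step a 1.5-fold higher number from compound 1 to compound 2 (0.16 log units; within the scatter) seen on the first core, which gives no reason to expect the change to move the value much. Since compound 3 already sits at the limit, compound 4 is estimated at 150000 nM, with a range from 60000 nM to 400000 nM, and most likely the assay will again report only a limit.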

Compound 4, half-maximal inhibitory concentration: > 100000 nM
Compound 4 was reported as a limit; the forecaster's own chance of this, stated with the estimate: 80%; the middle value is on the limit's open side.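

In this assay compound 4 gives > 100000 nM as a limit of the assay, not a number. Compound 3 is also reported only as a limit, so no step can be read between compound 3 and compound 4: (the limit of > 100000 nM in this assay, at which 2 of the 4 values shown sit). The compounds shown leave open how far amino in place of nitro moves the value on the core of compound 3.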